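Acyl chain end: amino in place of methoxy

The source may hold more compounds than are shown below. What is called first, only, known or untested is meant among the compounds shown, and "the series" means these compounds.

Within the data shown here, in an ADME assay on CCRF-CEM cells (Homo sapiens) for cytotoxicity, with a stated time of 4 days (a lower number here means that less compound is tolerated, a higher number that more compound is tolerated), two compounds have numbers so far. Compound 1 `Cc1cn([C@@H]2O[C@H](CO[Si](C)(C)C(C)(C)C)[C@@]3(OS(=O)(=O)C=C3N)[C@H]2O[Si](C)(C)C(C)(C)C)c(=O)n(C(=O)C2CC2)c1=O` gives 11000 nM, and compound 2 `COC(=O)CCCC(=O)n1c(=O)c(C)cn([C@@H]2O[C@H](CO[Si](C)(C)C(C)(C)C)[C@@]3(OS(=O)(=O)C=C3N)[C@H]2O[Si](C)(C)C(C)(C)C)c1=O` gives 9900 nM. These values lie within the scatter of each other, so compound 2 stands level with compound 1.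

Compound 3 `Cc1cn([C@@H]2O[C@H](CO[Si](C)(C)C(C)(C)C)[C@@]3(OS(=O)(=O)C=C3N)[C@H]2O[Si](C)(C)C(C)(C)C)c(=O)n(C(=O)CCCC(N)=O)c1=O` alters only the end of the chain in compound 2, with amino in place of methoxy on a carbonyl carbon. Cut one bond further out, this reads methoxycarbonyl to carbamoyl.

Among the measured compounds shown here, only one measured step bears on this change: a 1.1-fold lower number from compound 1 to compound 2 (0.05 log units; within the scatter). That step put 3-(methoxycarbonyl)propyl in place of cyclopropyl on a carbonyl carbon, so it shows a large change to this group staying within the scatter. For the measured compounds named here, it does not test amino against methoxy, and no measured compound carries carbamoyl, so the range is kept wide.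

No step beyond the scatter is therefore expected in this assay, and no direction is favoured. The estimated step is a 1.0-fold higher number from compound 2 to compound 3 (0.00 log units; within the scatter). Compound 3 is expected at 10000 nM, with an estimated range of 4500 nM to 23000 nM.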

Compound 3, half-maximal cytotoxic concentration: 8700 nM
Compound 3: the middle estimate sits 1.1-fold (0.06 log units) above what was measured, and the stated range covers the measured number.
By their numbers in this assay, from the lowest: compounds 3, 2 and 1 (each within the scatter of the next).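

In this assay the chain end now has a direct test: amino in place of methoxy on a carbonyl carbon gives a 1.1-fold lower number from compound 2 to compound 3 (0.06 log units; within the scatter), so methoxycarbonyl and carbamoyl cannot be told apart here, even though the swap removes a hydrogen-bond acceptor and brings in a hydrogen-bond donor. Set against the short group, the new chain gives a 1.3-fold lower number from compound 1 to compound 3 (0.10 log units; within the scatter), which places 3-carbamoylpropyl level with cyclopropyl on this carbonyl carbon, as 3-(methoxycarbonyl)propyl already was, and leaves all three compounds within the scatter of one another. No supporting measurement is available to account for this flat picture.

Still open, as far as these compounds go, is whether a carboxylic acid or an amine at the chain end, or a chain longer than those seen so far, would move the number beyond the scatter. Also open, from the compounds shown here alone, is whether the same flat picture would hold with a phenyl ring on this carbonyl carbon, since the groups compared so far are cyclopropyl and two saturated chains with a carbonyl end.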